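The source may hold more compounds than are shown below. What is called first, only, known or untested is meant among the compounds shown, and "the series" means these compounds.

Measured compounds:
- compound 1 `C=CC(=O)N1CC(NC(=O)Cn2cc(C(=O)N(C)Cc3ccccc3)c3cc(Br)ccc32)C1`: 1.67 h
- compound 2 `C=CC(=O)N1CC(NC(=O)Cn2cc(C(=O)NCc3ccccc3)c3cc(Br)ccc32)C1`: 1.67 h

For the measured compounds named here, in a physicochemical assay for pharmacokinetics, read by LC-MS, in phosphate buffer, at pH 7.4, in the presence of a further agent that is not named here (on this read-out higher numbers stand for a longer-lived compound and lower numbers for a shorter-lived compound), compound 2 gives 1.67 h and stands level with compound 1, which gives 1.67 h; the only measured step, no change at the digits printed from compound 1 to compound 2 (within the scatter), lies within the scatter. Compound 3 `C=CC(=O)N1CC(NC(=O)Cn2ccc3cc(Br)ccc32)C1` differs from compound 2 by hydrogen in place of benzylcarbamoyl on an aromatic carbon. Going by the values given here, no measured step touches this part of the core; the single step in hand, at an amide-type nitrogen, was flat. The expected step is therefore none beyond the scatter, a 1.0-fold higher number from compound 2 to compound 3 (0.01 log units; within the scatter). For compound 3 the estimate in this assay is 1.7 h, within 0.8 h to 3.5 h.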

Compound 3, half-life: 1.67 h
Compound 3: the middle estimate sits 1.0-fold (0.01 log units) above what was measured; low and high end bracket the measured number.
By their numbers in this assay, from the lowest: compounds 1, 2 and 3 (each within the scatter of the next).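

In this assay the whole benzylcarbamoyl can leave this aromatic carbon of the five-membered aromatic ring, with its six-membered aromatic ring, donor and acceptor, and the read-out gives (no change at the digits printed from compound 2 to compound 3 (within the scatter)). Removing the benzyl(methyl)carbamoyl gives the same picture (no change at the digits printed from compound 1 to compound 3 (within the scatter)). The flat result is therefore no longer confined to the amide-type nitrogen but holds for the loss of the entire substituent, and no evidence in hand bears on the reason.

Open, going by these compounds, is whether a carboxylic acid or an amine on this carbon would leave the half-life equally flat. Also open, on these data alone, is what replacing the bromine or the acryloyl group on the shared core would do.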